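Swapping the benzyl ether arm for a carboxylic acid

The compounds below may be only part of what the source reports. "The series", "measured", "known", "first", "only" and "open" are said of these compounds alone.

Of the compounds shown here, two built on the same long saturated chain have been measured in an ADME assay on cells (Splenocyte, Mus musculus, strain BALB/c) for cytotoxicity, read by MTT assay, tested at 10 ug/mL; on this read-out higher numbers stand for a stronger effect at the one concentration tested and lower numbers for a weaker effect. Compound 1 `CCCCCCCCCCCCCCC(COCc1ccccc1)NC(=O)CCCC(=O)OC` carries an amide-linked ester arm and gives 2.5%. Compound 2 `CCCCCCCCCCCCCCC(COCc1ccccc1)N(CC)CC` carries a diethylamine in that position and gives 15.6%. Within the data shown here, the single measured step, a number 13.1 percentage points higher from compound 1 to compound 2 (beyond the scatter), is a modest rise, and it places compound 2 as the higher of the two numbers, with compound 1 standing below it by an amount beyond the scatter.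

Compound 3 `CCCCCCCCCCCCCCC(C(=O)O)N(CC)CC` keeps the diethylamine and the long chain of compound 2 but alters the other arm: carboxy in place of (benzyloxy)methyl on a saturated chain carbon bound to an amine nitrogen and a saturated chain carbon. Among the measured compounds shown here, this change sits at a different place from the one measured step, so that step offers no direct guide to its size or direction. With nothing measured on this arm, the most defensible expectation is a number near that of compound 2, with wide uncertainty in both directions; the estimated step is a number 3.6 percentage points lower from compound 2 to compound 3 (within the scatter). Compound 3 is therefore expected to give about 12% in this assay, within a range from 0% to 32%.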

Compound 3, a percentage reported as activity, at one concentration (the size of the read-out at that concentration, not a potency): 12.1%
Estimate against measurement, compound 3: 0.1 percentage points below, within the range that was stated.
By their numbers in this assay, from the lowest: compounds 1, 3 and 2 (each within the scatter of the next, the first and the last beyond it).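

In this assay, putting carboxy in place of (benzyloxy)methyl gives a number 3.5 percentage points lower from compound 2 to compound 3 (within the scatter), so this exchange has no effect that can be told apart from ordinary assay variation. The change is a substantial one: a six-membered aromatic ring leaves, a smaller group with no ring enters, and a hydrogen-bond donor is added, yet on a saturated chain carbon bound to an amine nitrogen and a saturated chain carbon the read-out at this single concentration does not distinguish the two groups, at least while the diethylamine and the long chain stay in place. No supporting measurement is available to explain why the read-out tolerates this exchange.

The two groups tested on this carbon still leave open whether a hydroxymethyl or a methyl ester would fit the same picture, or whether a group of another kind, such as a primary amine, would separate itself from them. As far as these compounds go, it also remains open whether carboxy would behave the same way with a shorter chain or with the amide-linked ester arm of compound 1 on the nitrogen.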